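From 1-methoxyethyl to oxan-4-yl on a shared core

This account rests on a few compounds, and the source may have more. Where it says the series, first, only, none or still open, it means among the compounds named here.

Values so far in a physicochemical assay for lipophilicity; a higher number here means a more lipophilic compound, a lower number a more polar compound
- compound 1 `O=C(Nc1cnc(-n2nccn2)c(Cl)c1)Nc1cnc2cc(Cl)nn2c1C1CC1` 3.2
- compound 2 `CO[C@@H](C)c1c(NC(=O)Nc2cnc(-n3nccn3)c(Cl)c2)cnc2cc(Cl)nn12` 3.4

Within the data shown here, compound 2, at 3.4, stands within the scatter of the only other measured compound. Among the measured compounds shown here, the one measured step is a number 0.20 log units higher from compound 1 to compound 2 (within the scatter), with 1-methoxyethyl in place of cyclopropyl on an aromatic carbon.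

Compound 3 `O=C(Nc1cnc(-n2nccn2)c(Cl)c1)Nc1cnc2cc(Cl)nn2c1C1CCOCC1` is still unmeasured. It carries oxan-4-yl in place of 1-methoxyethyl on an aromatic carbon. For the measured compounds named here, no measured compound carries oxan-4-yl, so the guide is thin: only that single step at the same place, which stayed within the scatter. No step beyond the scatter is therefore expected in this assay, in either direction. The estimated step is a number 0.20 log units lower from compound 2 to compound 3 (within the scatter). Compound 3 is expected at 3.2, with an estimated range of 2.8 to 3.6.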

Compound 3, partition coefficient: 3
The estimate for compound 3 lay 0.20 log units above the measured number, within the range that was stated.
By their numbers in this assay, from the lowest: compounds 3, 1 and 2 (each within the scatter of the next, the first and the last beyond it).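

In this assay this position now gives a step beyond the scatter: putting oxan-4-yl in place of 1-methoxyethyl gives a number 0.40 log units lower from compound 2 to compound 3 (beyond the scatter) on the shared core, so the position does not respond alike to every group placed there. Oxan-4-yl in place of cyclopropyl gives a number 0.20 log units lower from compound 1 to compound 3 (within the scatter) in the same assay, so these two rings cannot be told apart by this measurement. 1-Methoxyethyl and oxan-4-yl each count one hydrogen-bond acceptor and no donors, but they differ in heavy atoms, ring and defined stereocentre, and no measurement shown here says which of these differences accounts for the step.

Still open, as far as these compounds go, is how this position responds to an amine such as piperidin-4-yl, or to a carboxylic acid. Also open, from the compounds shown here alone, is how the mirror-image form of 1-methoxyethyl compares.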